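A Third Variation at One Aromatic Carbon

The source may report more compounds than this note shows. Statements on the series, on what has been measured and on what is new or still open speak of the compounds shown alone.

Compound 1, `CCCc1nc(CC)c(C(=O)OCc2ccccc2OC)n1Cc1ccc(-c2ccccc2S(=O)(=O)NC(=O)OCCC(C)C)cc1F`, gives 1 nM in an assay on isolated protein for binding affinity to Type-2 angiotensin II receptor (Homo sapiens); on this read-out lower numbers stand for stronger inhibition and higher numbers for weaker inhibition.
Compound 2, `CCCc1nc(CC)c(C(=O)OCc2ccccc2NC(=O)c2ccccc2)n1Cc1ccc(-c2ccccc2S(=O)(=O)NC(=O)OCCC(C)C)cc1F`, gives 1 nM in this assay.

Compound 2 stands level with compound 1 at the digits shown. Going by the values given here, the only measured step, no change at the digits printed from compound 1 to compound 2 (within the scatter), lies within the scatter. Compound 3, `CCCc1nc(CC)c(C(=O)OCc2ccccc2Sc2ccccc2)n1Cc1ccc(-c2ccccc2S(=O)(=O)NC(=O)OCCC(C)C)cc1F`, carries phenylsulfanyl in place of benzamido on an aromatic carbon. Among the compounds with values here, that single flat step is the only guide for this change, so no shift beyond the scatter is expected in this assay. Compound 3 is therefore estimated at 1 nM, in the range 0.4 nM to 3 nM, which means an expected step of no change at the digits printed from compound 2 to compound 3 (within the scatter).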

Compound 3, half-maximal inhibitory concentration: 2 nM
For compound 3 the middle estimate is 2.0-fold (0.30 log units) below the measured one, and the stated range covers the measured number.
By their numbers in this assay, from the lowest: compounds 1, 2 and 3 (each within the scatter of the next).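

In this assay the swap of benzamido for phenylsulfanyl gives a 2.0-fold higher number from compound 2 to compound 3 (0.30 log units; within the scatter) and the swap of methoxy for phenylsulfanyl gives a 2.0-fold higher number from compound 1 to compound 3 (0.30 log units; within the scatter). A third group on this aromatic carbon therefore stays level with the other two, even though the hydrogen-bond donor of benzamido is gone and a sulfur now carries the ring. No data are available that explain why these numbers stay so close. Still open, as far as these compounds go, is whether an amine, a carboxylic acid or a longer chain on this carbon would also stay within the scatter.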